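Estimating a bromo analogue of a bis(pyridyl)hydrazone series

This account rests on a few compounds, and the source may have more. Where it says the series, first, only, none or still open, it means among the compounds named here.

Of the compounds shown here, three sharing one core have been measured in an ADME assay on cells (Homo sapiens) for antiproliferative activity, read by MTT assay; a higher number here means a weaker inhibitor, a lower number a stronger inhibitor. Compound 1 `O=C(NN=C(c1ccccn1)c1ccccn1)c1ccc([N+](=O)[O-])cc1` gives 260 nM, compound 2 `Nc1ccc(C(=O)NN=C(c2ccccn2)c2ccccn2)cc1` gives 7640 nM, and compound 3 `O=C(NN=C(c1ccccn1)c1ccccn1)c1ccccc1` gives 3040 nM, which places compound 3 second highest of the three. The steps at the same aromatic carbon were a 12-fold higher number from compound 1 to compound 3 (1.07 log units; beyond the scatter) and a 2.5-fold lower number from compound 2 to compound 3 (0.40 log units; beyond the scatter). Compound 4 `O=C(NN=C(c1ccccn1)c1ccccn1)c1ccc(Br)cc1` differs from compound 3 by bromo in place of hydrogen on an aromatic carbon, on an aromatic carbon of a six-membered aromatic ring of carbon only, para to a large group. Among the compounds with values here, no measured step carries bromo, so the expectation rests only on the spread seen across compounds 1, 2 and 3. Compound 4 is expected to show a 2.5-fold lower number from compound 3 to compound 4 (0.40 log units; beyond the scatter), with an estimate of 1200 nM and a range from 300 nM to 5000 nM.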

Compound 4, half-maximal inhibitory concentration: 300 nM
For compound 4 the middle estimate is 4.0-fold (0.60 log units) above the measured one, and the stated range covers the measured number.
By their numbers in this assay, from the lowest: compounds 1 and 4 (each within the scatter of the next); then compound 3; then compound 2.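

In this assay the change from phenyl to 4-bromophenyl is a large one, a 10-fold lower number from compound 3 to compound 4 (1.01 log units; beyond the scatter), and the distance to the amino analogue is larger still, a 25-fold lower number from compound 2 to compound 4 (1.41 log units; beyond the scatter). Nitro is therefore not the only group at this position to give a large step down from hydrogen, since the comparison of the two gives a 1.2-fold higher number from compound 1 to compound 4 (0.06 log units; within the scatter). Nothing available here explains why these two groups match. As far as these compounds go, whether chloro, methyl or a carboxylic acid on the same carbon would behave like bromo and nitro remains open, as does the effect of bromo on another carbon of this ring.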